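The source may report more compounds than this note shows. Statements on the series, on what has been measured and on what is new or still open speak of the compounds shown alone.

Compound 1 `O=C(CSC(=S)N[C@H]1CCOC1=O)Nc1ccc(C(=O)/C=C/c2ccc(Cl)cc2)cc1`: 20300 nM
Compound 2 `O=C(CSC(=S)N[C@H]1CCOC1=O)Nc1ccc(C(=O)/C=C/c2ccc(Br)cc2)cc1`: 18700 nM

Both numbers come from a functional assay on MCF7 cells (Homo sapiens) for cytotoxicity, read by MTT assay, with a stated time of 72 h; a lower number here means a stronger inhibitor, a higher number a weaker inhibitor. Compound 2 gives the lower of the two, yet a 1.1-fold lower number from compound 1 to compound 2 (0.04 log units; within the scatter) lies within the scatter, so the two compounds read alike. Compound 3 `O=C(CSC(=S)N[C@H]1CCOC1=O)Nc1ccc(C(=O)/C=C/c2ccccc2Cl)cc1` carries 2-chlorophenyl in place of 4-bromophenyl on a double-bonded chain carbon bound to a double-bonded chain carbon. Going by the values given here, the one measured step, a 1.1-fold lower number from compound 1 to compound 2 (0.04 log units; within the scatter), exchanged one halogen for another and changed nothing beyond the scatter; no measured step shows a halogen moved to a different ring position. The expectation is therefore a 1.1-fold higher number from compound 2 to compound 3 (0.03 log units; within the scatter) in this assay, with a wide range. Compound 3 is estimated at 20000 nM, between 7000 nM and 60000 nM.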

Compound 3, half-maximal inhibitory concentration: 5570 nM
Estimate against measurement, compound 3: 3.6-fold (0.56 log units) above; measured number below the stated range.
By their numbers in this assay, from the lowest: compound 3; then compounds 2 and 1 (each within the scatter of the next).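

In this assay, among these compounds, the place of the halogen on the ring matters more than its identity: keeping chlorine but using 2-chlorophenyl in place of 4-chlorophenyl gives a 3.6-fold lower number from compound 1 to compound 3 (0.56 log units; beyond the scatter), and 2-chlorophenyl in place of 4-bromophenyl gives a 3.4-fold lower number from compound 2 to compound 3 (0.53 log units; beyond the scatter). Going by these compounds alone, the earlier exchange of chlorine for bromine stayed within the scatter, so this is the first change here to move the number beyond it. Nothing measured here explains the gain. On these data alone, whether 2-bromophenyl would read like compound 3 stays open, as does the effect of an amine or a carboxylic acid in place of the chlorine.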